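Cytotoxicity notes on compounds 1 to 4

The compounds below may be only part of what the source reports. "The series", "measured", "known", "first", "only" and "open" are said of these compounds alone.

Measured so far:
compound 1, `CC(C)(C)OC(=O)Nc1ncc(C(Oc2ccc(OCc3ccccc3)cc2)c2ccc(Cl)cc2)s1`: > 50000 nM
compound 2, `O=C(Nc1ncc(C(OCc2ccc(Cl)cc2)c2ccccc2)s1)c1cccs1`: "not toxic" (no number reported)
compound 3, `O=C(Nc1ncc(C(Oc2ccc3cc(Br)ccc3c2)c2ccc(Cl)cc2)s1)c1ccccc1`: "not toxic" (no number reported)

In an ADME assay on HepG2 2.2.15 cells (Homo sapiens) for cytotoxicity (a higher number here means that more compound is tolerated, a lower number that less compound is tolerated), compound 1 reaches only a limit of the assay, > 50000 nM. Compound 2 is recorded in this assay as "not toxic" (no number reported), without a number. Compound 3 likewise stands in this assay as "not toxic" (no number reported), again without a number, so it cannot be placed on a scale against the other two. Of the three values shown, one is the limit of > 50000 nM in this assay, at which 1 of the 3 values shown sits, and the other two carry no number at all.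

Compound 4, `O=S(=O)(Nc1ncc(C(Oc2ccc3cc(Br)ccc3c2)c2ccc(Cl)cc2)s1)c1ccc(Cl)cc1`, differs from compound 3 by (4-chlorophenyl)sulfonyl in place of benzoyl on a nitrogen on an aromatic ring. For the measured compounds named here, no measured step between any two compounds in this assay is available to size this change, and the expectation is a step of none beyond the scatter. Compound 4 is therefore estimated at 50000 nM, within 15000 nM to 100000 nM, with a fair chance that the assay again reports only a limit.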

Compound 4, half-maximal cytotoxic concentration: "not toxic" (no number reported)
For compound 4 the study gives words and no number; there is nothing to compare the estimate with.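

Compound 3 and compound 4 are both recorded in words only in this assay, so no step can be read for benzoyl giving way to (4-chlorophenyl)sulfonyl. The compounds shown leave open at what concentration any of them becomes cytotoxic: the limit of > 50000 nM in this assay, at which 1 of the 4 values shown sits.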